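Adding a 3-chlorophenyl group to compound 2

A few compounds are considered here, and "the series" means these few. Any claim that something is new, unique, unknown or untested is made for them only; others in the source may bear on it.

Compound 1 `C=CC(=O)N1C(=O)CC(c2ccc(Br)cc2)Sc2ccccc21` gives 51300 nM 
Compound 2 `C=CC(=O)N1C(=O)CCSc2ccccc21` gives 581000 nM 

In a functional assay on Raji cells (Homo sapiens) for cytotoxicity, read by CCK-8 assay, with a stated time of 24 h (on this read-out lower numbers stand for stronger inhibition and higher numbers for weaker inhibition), compound 2 holds the higher of the two numbers, at 581000 nM against the lower value of compound 1. Compound 3 `C=CC(=O)N1C(=O)CC(c2cccc(Cl)c2)Sc2ccccc21` carries 3-chlorophenyl in place of hydrogen on a saturated ring carbon. Among the measured compounds shown here, the one measured step bearing on this is the reverse kind of change, hydrogen in place of 4-bromophenyl on a saturated ring carbon, and it was large, with an 11-fold higher number from compound 1 to compound 2 (1.05 log units; beyond the scatter) and thus beyond the scatter. For the measured compounds named here, no measured compound carries 3-chlorophenyl, yet a fall of similar size is expected, estimated as an 11-fold lower number from compound 2 to compound 3 (1.02 log units; beyond the scatter) on this basis. For compound 3 the estimated value is 55000 nM within an expected range of 20000 nM to 150000 nM for this measurement.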

Compound 3, half-maximal inhibitory concentration: 47100 nM
For compound 3 the middle estimate is 1.2-fold (0.07 log units) above the measured one; measured number inside the range.
By their numbers in this assay, from the lowest: compounds 3 and 1 (each within the scatter of the next); then compound 2.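

Placing 3-chlorophenyl on the saturated ring carbon next to the ring sulfur gives a 12-fold lower number from compound 2 to compound 3 (1.09 log units; beyond the scatter) in this assay, so the fall seen with 4-bromophenyl is not unique to that group. Replacing 4-bromophenyl with 3-chlorophenyl gives a 1.1-fold lower number from compound 1 to compound 3 (0.04 log units; within the scatter), so this exchange of halogen and its ring position, made together, leaves the two compounds indistinguishable. As far as these compounds go, whether an unsubstituted phenyl, an aminophenyl or a saturated cyclohexyl group on this carbon would give a similar number remains open. No available evidence explains these numbers.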